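Aryl in Place of Ethyl on a Ring Amine Nitrogen

A few compounds are considered here, and "the series" means these few. Any claim that something is new, unique, unknown or untested is made for them only; others in the source may bear on it.

Three compounds were measured in a physicochemical assay for lipophilicity, read by spectrophotometry, using the shake flask method, measured as octanol-water partition, with a stated time of 24 h; a lower number here means a more polar compound, a higher number a more lipophilic compound:

Compound 1, `CN1CCN(CC(=O)Nc2nc3ccccc3[nH]2)CC1`: 1.67
Compound 2, `CCN1CCN(CC(=O)Nc2nc3ccccc3[nH]2)CC1`: 1.09
Compound 3, `O=C(CN1CCN(c2ncccn2)CC1)Nc1nc2ccccc2[nH]1`: 1.85

Compound 2 stands lowest of the three. The step of a number 0.58 log units lower from compound 1 to compound 2 (beyond the scatter) shows that lengthening the group on the ring nitrogen by one carbon lowered the reading, while a number 0.76 log units higher from compound 2 to compound 3 (beyond the scatter) shows that an aromatic ring on that nitrogen raised it again, and a number 0.18 log units higher from compound 1 to compound 3 (within the scatter) lies within the scatter.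

Compound 4, `COc1ccc(N2CCN(CC(=O)Nc3nc4ccccc4[nH]3)CC2)cc1`, differs from compound 2 in one place: 4-methoxyphenyl in place of ethyl on an amine nitrogen in a ring.

The step that bears most directly on this change is a number 0.76 log units higher from compound 2 to compound 3 (beyond the scatter), since it also replaces the ethyl on the ring nitrogen with an aromatic ring. The entering 4-methoxyphenyl is a larger group than the pyrimidin-2-yl of compound 3, so a step of at least that size upward is expected, a number 1.31 log units higher from compound 2 to compound 4 (beyond the scatter). Compound 4 is therefore estimated at 2.4, with a range from 1.8 to 3.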

Compound 4, partition coefficient: 2.65
Compound 4: the middle estimate sits 0.25 log units below what was measured; measured number inside the range.
By their numbers in this assay, from the lowest: compound 2; then compounds 1 and 3 (each within the scatter of the next); then compound 4.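

In this assay, for the compounds shown here, swapping the ethyl on the ring amine nitrogen for 4-methoxyphenyl gives a number 1.56 log units higher from compound 2 to compound 4 (beyond the scatter), the only step in this set printed as large. Aromatic rings at this position are not interchangeable: exchanging pyrimidin-2-yl for 4-methoxyphenyl gives a number 0.80 log units higher from compound 3 to compound 4 (beyond the scatter), and while pyrimidin-2-yl stayed within the scatter of methyl, 4-methoxyphenyl in place of methyl gives a number 0.98 log units higher from compound 1 to compound 4 (beyond the scatter). Nothing available here explains why these groups differ.

Plain phenyl on the same nitrogen would help to separate what the aromatic ring contributes from what the methoxy group contributes to this rise. A propyl group at this position would show whether the lower number seen on going from methyl to ethyl continues along a longer chain.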